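Swapping a chain amine for a hydroxypiperidine

The source may report more compounds than this note shows. Statements on the series, on what has been measured and on what is new or still open speak of the compounds shown alone.

Compound 1 `O=c1cc(-c2ccccc2)oc2cccc(OCCCCN3CCC(O)CC3)c12` and compound 2 `CN(C)CCCCCCCOc1ccc2oc(-c3ccccc3)cc(=O)c2c1` share the same core and differ in the side chain on the ether oxygen. In an assay on isolated protein (Cavia porcellus) with Sigma non-opioid intracellular receptor 1 (Homo sapiens) as the target, read by radioligand binding (a lower number here means a stronger inhibitor, a higher number a weaker inhibitor), compound 1 gives 177 nM, and compound 2 gives 188 nM; these two numbers lie within the usual scatter of each other, so neither stands apart. Compound 3 `O=c1cc(-c2ccccc2)oc2ccc(OCCCN3CCC(O)CC3)cc12` has not yet been measured. It carries 4-hydroxypiperidin-1-yl in place of 4-(dimethylamino)butyl on a saturated chain carbon, three bonds along the chain from an oxygen on an aromatic ring. Compound 1 already holds the 4-hydroxypiperidin-1-yl group and gives 177 nM. The step from compound 2 to compound 3 in this assay is therefore expected to be a 1.3-fold lower number from compound 2 to compound 3 (0.10 log units; within the scatter), not beyond the scatter. Compound 3 is estimated at 150 nM, within a range from 50 nM to 500 nM.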

Compound 3, half-maximal inhibitory concentration: 123 nM
Beside the measured number, compound 3's estimate is 1.2-fold (0.09 log units) above it; the measured number falls inside the stated range.
By their numbers in this assay, from the lowest: compounds 3, 1 and 2 (each within the scatter of the next).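

In this assay, replacing 4-(dimethylamino)butyl with 4-hydroxypiperidin-1-yl on a saturated chain carbon, three bonds along the chain from an oxygen on an aromatic ring, gives a 1.5-fold lower number from compound 2 to compound 3 (0.18 log units; within the scatter). Among these compounds, this is the first direct comparison of the two groups at one place. An open chain ending in dimethylamino and a six-membered ring carrying a hydrogen-bond donor cannot be told apart here. As far as these compounds go, whether a morpholin-4-yl group or a carboxylic acid would also stay within the scatter remains open. The reason for this result also remains open, as no supporting measurement bears on it.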